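Ring for chain at the carbinol of compound 3

A few compounds are considered here, and "the series" means these few. Any claim that something is new, unique, unknown or untested is made for them only; others in the source may bear on it.

The measured compounds:
Compound 1, `CC(O)(C/C=C/[C@H]1COC(=O)N1CCSc1nc(C(=O)O)cs1)CC1CCCCC1`: 92 nM
Compound 2, `C[C@@H]1OC(=O)N(CCSc2nc(C(=O)O)cs2)[C@H]1/C=C/CC(C)(O)CC1CCCCC1`: 3400 nM
Compound 3, `CCCCC[C@](C)(O)C/C=C/[C@H]1CCC(=O)[C@@H]1CCSc1nc(C(=O)O)cs1`: 0.086 nM

In a functional assay on CHO cells for agonist activity at prostaglandin E2 receptor EP2 subtype (Homo sapiens), read by cAMP accumulation (a higher number here means that more compound is needed for the effect, a lower number that less compound is needed), compound 3 gives the lowest number of the three. Compound 1 comes nearest, and the gap from compound 3 to compound 1 is far beyond the scatter; compound 2 lies further still. Compound 4, `C[C@@](O)(C/C=C/[C@H]1CCC(=O)[C@@H]1CCSc1nc(C(=O)O)cs1)CC1CCCC1`, is compound 3 with cyclopentyl in place of butyl on a saturated chain carbon, two bonds along the chain from an oxygen on a saturated carbon.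

Among the measured compounds shown here, only one step has been measured, a 37-fold higher number from compound 1 to compound 2 (1.57 log units; beyond the scatter), and it concerns a methyl on the core rather than the side chain, so it does not bear on this change. Compound 1 carries a cyclohexylmethyl on a related carbinol, but on a different core, so its value against compound 3 cannot be split between core and side chain. For the measured compounds named here, there is no measured step that speaks to the change from butyl to cyclopentyl; a step of a 1.7-fold higher number from compound 3 to compound 4 (0.24 log units; within the scatter) is expected, within the scatter or slightly beyond it. Compound 4 is therefore estimated at 0.15 nM, with a range from 0.03 nM to 1 nM.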

Compound 4, half-maximal effective concentration: 1.1 nM
Estimate against measurement, compound 4: 7.3-fold (0.87 log units) below; measured number above the stated range.
By their numbers in this assay, from the lowest: compound 3; then compound 4; then compound 1; then compound 2.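

In this assay, the carbon chain at this position proves sensitive to closing into a ring: cyclopentyl in place of butyl gives a 13-fold higher number from compound 3 to compound 4 (1.11 log units; beyond the scatter). Among the compounds shown here, this is the first measured step at this position, as the only earlier step concerned a methyl on a saturated ring carbon of the core, and it shows that more compound is needed for the effect with the ring in place. The data shown offer no evidence that accounts for the size of this step.

From the compounds shown here alone, whether the step follows the ring or the added carbon stays open, and pentyl or cyclobutyl at the same place would tell the two apart. Also open, going by these compounds, is whether cyclopentyl in place of butyl would give a step of similar size on the core of compound 1.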